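The compounds below may be only part of what the source reports. "The series", "measured", "known", "first", "only" and "open" are said of these compounds alone.

Compound 1 `O=C(Nc1ccc(-c2ncccc2C(F)(F)F)cc1)c1ccc(C(F)(F)F)cc1` gives 24 nM in a functional assay on CHO cells for antagonist activity at transient receptor potential cation channel subfamily V member 1 (Homo sapiens), read by FLIPR; a higher number here means a weaker inhibitor, a lower number a stronger inhibitor. Compound 2 `O=C(Nc1ccc(-c2ccccn2)cc1)c1ccc(C(F)(F)F)cc1` gives 1500 nM. Compound 3 `O=C(Nc1ccc(-c2ncccc2C(F)(F)F)cc1)c1ccccc1` gives 2400 nM.

Compound 3 carries the highest number of the three. Its nearest neighbour is compound 2, and these two values lie within the scatter of each other, so nothing separates them; the step from compound 1 to compound 3 is a 100-fold higher number from compound 1 to compound 3 (2.00 log units; beyond the scatter), so compound 3 is clearly weaker than compound 1.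

Compound 4 `CC(C)(C)c1ccc(C(=O)Nc2ccc(-c3ncccc3C(F)(F)F)cc2)cc1` differs from compound 3 by tert-butyl in place of hydrogen on an aromatic carbon. Within the data shown here, of the measured steps, only the one from compound 1 to compound 3 bears on this place: removing trifluoromethyl there gave a 100-fold higher number from compound 1 to compound 3 (2.00 log units; beyond the scatter). The step from compound 1 to compound 2, a 63-fold higher number from compound 1 to compound 2 (1.80 log units; beyond the scatter), concerns a different ring and is not directly informative. Because compound 1 shows 24 nM with a group at this position while compound 3 shows 2400 nM with hydrogen, a large gain in this assay is expected when tert-butyl enters. The step from compound 3 to compound 4 is estimated at a 60-fold lower number from compound 3 to compound 4 (1.78 log units; beyond the scatter). Compound 4 is therefore expected to give about 40 nM, within a range of 10 nM to 200 nM.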

Compound 4, half-maximal inhibitory concentration: 470 nM
Compound 4: the middle estimate sits 12-fold (1.07 log units) below what was measured, outside the stated range (above it).
By their numbers in this assay, from the lowest: compound 1; then compound 4; then compounds 2 and 3 (each within the scatter of the next).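

In this assay, this place on the aromatic ring now shows a third outcome: with tert-butyl in place of hydrogen there is a 5.1-fold lower number from compound 3 to compound 4 (0.71 log units; beyond the scatter), so a group other than trifluoromethyl also improves on hydrogen, by a step beyond the scatter. The two groups are still not interchangeable, since tert-butyl in place of trifluoromethyl gives a 20-fold higher number from compound 1 to compound 4 (1.29 log units; beyond the scatter), and carrying a group at this place does not by itself reach the level of compound 1. Nothing available here explains the gap between tert-butyl and trifluoromethyl.

The compounds shown hold only hydrogen, trifluoromethyl and tert-butyl at this place, so how a methoxy group, a chlorine atom or an amine would rank there stays open. Also open, as far as these compounds go, is whether tert-butyl would bring a similar change on the core of compound 2.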